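An amino group for an ester on the terminal ring

The source may hold more compounds than are shown below. What is called first, only, known or untested is meant among the compounds shown, and "the series" means these compounds.

Three compounds share one core and differ only in the aryl group of the terminal amide. In an assay on isolated protein for inhibition of Rho-associated protein kinase 1 (Homo sapiens), read by scintillation counting, radiometric assay and 33P incorporation, with a stated time of 40 min, in the presence of a further agent that is not named here (on this read-out lower numbers stand for stronger inhibition and higher numbers for weaker inhibition), compound 1 `Cc1ccc(C(=O)Nc2cccc(NC(=O)COc3ccc4c(=O)ccoc4c3)c2)cc1` gives 183 nM; in this assay compound 2 `CCc1ccc(C(=O)Nc2cccc(NC(=O)COc3ccc4c(=O)ccoc4c3)c2)cc1` gives 235 nM; and compound 3 `COC(=O)c1ccc(C(=O)Nc2cccc(NC(=O)COc3ccc4c(=O)ccoc4c3)c2)cc1` gives 72 nM. Compound 3 stands lowest of the three numbers, set apart by a 2.5-fold lower number from compound 1 to compound 3 (0.41 log units; beyond the scatter) and a 3.3-fold lower number from compound 2 to compound 3 (0.51 log units; beyond the scatter), whereas a 1.3-fold higher number from compound 1 to compound 2 (0.11 log units; within the scatter). Compound 4 `Nc1cccc(C(=O)Nc2cccc(NC(=O)COc3ccc4c(=O)ccoc4c3)c2)c1` differs from compound 3 by 3-aminophenyl in place of 4-(methoxycarbonyl)phenyl on a carbonyl carbon. Both earlier steps bear on this change, since each altered the same aryl group, and both were modest. With the methoxycarbonyl gone, the number is expected to drift back towards those of compound 1 and compound 2. Compound 4 is therefore expected to give 190 nM, within 60 nM to 600 nM. The expected step is a 2.6-fold higher number from compound 3 to compound 4 (0.42 log units; beyond the scatter).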

Compound 4, half-maximal inhibitory concentration: 670 nM
The estimate for compound 4 lay 3.5-fold (0.55 log units) below the measured number, outside the stated range (above it).
By their numbers in this assay, from the lowest: compound 3; then compounds 1 and 2 (each within the scatter of the next); then compound 4.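

In this assay, 3-aminophenyl on this carbonyl carbon gives the highest number of the four compounds, with a 9.3-fold higher number from compound 3 to compound 4 (0.97 log units; beyond the scatter), a 2.9-fold higher number from compound 2 to compound 4 (0.46 log units; beyond the scatter) and a 3.7-fold higher number from compound 1 to compound 4 (0.56 log units; beyond the scatter). Going by these compounds alone, the aryl group at this position therefore spans a wider range than the earlier compounds showed, and losing 4-(methoxycarbonyl)phenyl does not simply return the number to those of the alkyl-bearing compounds but goes past them. Nothing available explains this step.

The compounds shown do not separate the loss of the ester from the arrival of the amine. On these data alone, whether a carboxylic acid or a primary amide on this aryl group would hold the number near that of compound 3 remains open.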